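The source may hold more compounds than are shown below. What is called first, only, known or untested is meant among the compounds shown, and "the series" means these compounds.

Values measured so far in an ADME assay on NIH3T3 cells (Mus musculus) for cytotoxicity, read by MTT assay, with a stated time of 48 h; on this read-out higher numbers stand for lower toxicity in this test and lower numbers for higher toxicity in this test

Compound 1 `COc1ccc(C(=O)/C=C/c2ccccc2)cc1S(N)(=O)=O` gives 7700 nM
Compound 2 `COc1ccc(C(=O)/C=C/c2ccc(Cl)cc2)cc1S(N)(=O)=O` gives 4100 nM
Compound 3 `COc1ccc(C(=O)/C=C/c2ccc(C)cc2)cc1S(N)(=O)=O` gives 4300 nM

Compound 3 has no clear place among these three numbers. One gap is tiny (a 1.0-fold higher number from compound 2 to compound 3 (0.02 log units; within the scatter)) and the other is also small (a 1.8-fold lower number from compound 1 to compound 3 (0.25 log units; within the scatter)), so it cannot be told apart from either of the other two.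

The next compound is compound 4 `COc1ccc(/C=C/C(=O)c2ccc(OC)c(S(N)(=O)=O)c2)cc1`, which keeps the shared core and changes a single group. It carries methoxy in place of methyl on an aromatic carbon, turning 4-methylphenyl into 4-methoxyphenyl (methoxy in place of methyl on an aromatic carbon). For the measured compounds named here, no measured compound has methoxy there, so only the nearby steps can guide an expectation. Chloro in place of hydrogen gave a modest step (a 1.9-fold lower number from compound 1 to compound 2 (0.27 log units; within the scatter)), as did methyl in place of hydrogen (a 1.8-fold lower number from compound 1 to compound 3 (0.25 log units; within the scatter)), and methyl in place of chloro gave almost none (a 1.0-fold higher number from compound 2 to compound 3 (0.02 log units; within the scatter)). All three stayed within the scatter, although three compounds are a thin basis. Methoxy is therefore expected to bring no step beyond the scatter in this assay as well.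

The estimated change is small (a 1.0-fold higher number from compound 3 to compound 4 (0.02 log units; within the scatter)) and carries no firm direction. For compound 4 the estimated value is 4500 nM, with an expected range from 2200 nM to 9000 nM.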

Compound 4, concentration lethal to 50% of the cells: 96000 nM
Compound 4: middle estimate off by 21-fold (1.33 log units), on the low side, outside the stated range (above it).
By their numbers in this assay, from the lowest: compounds 2, 3 and 1 (each within the scatter of the next); then compound 4.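

In this assay, this spot on the aromatic ring, para to a large group, proves far more sensitive than hydrogen, chloro and methyl had suggested, with a 22-fold higher number from compound 3 to compound 4 (1.35 log units; beyond the scatter) for methoxy in place of methyl, a 23-fold higher number from compound 2 to compound 4 (1.37 log units; beyond the scatter) for methoxy in place of chloro and a 12-fold higher number from compound 1 to compound 4 (1.10 log units; beyond the scatter) for methoxy in place of hydrogen. All three steps are beyond the scatter and point the same way, towards lower toxicity in this test, so compound 4 stands clear of the other three, and a small swap from methyl with 1 heavy atom to methoxy with 2 heavy atoms and 1 hydrogen-bond acceptor goes with a large change in the read-out. Nothing among the data shown explains this jump.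

Among the compounds shown, only compound 4 carries methoxy, so it remains open whether the large step is particular to methoxy or would also appear with a hydroxyl, an ethoxy group or an amine at this spot. Going by these compounds, it also remains open whether methoxy would have the same effect at another place on the ring.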